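The source may report more compounds than this note shows. Statements on the series, on what has been measured and on what is new or still open speak of the compounds shown alone.

Compound 1 `Cc1ccc2[nH]c(=O)c(CN(Cc3ccc(OCC(=O)O)cc3)Cc3ccc(C(C)(C)C)cc3)cc2c1`: in a toxicity assay on MDCK cells (Canis lupus familiaris) for cytotoxicity, read by crystal violet staining, with a stated time of 48 h (on this read-out higher numbers stand for lower toxicity in this test and lower numbers for higher toxicity in this test), compound 1 gives > 10000 nM, a limit of the test rather than a number.
Compound 2 `CCCOc1ccc(CN(Cc2ccc(C(C)(C)C)cc2)Cc2cc3cc(C)ccc3[nH]c2=O)cc1`: in this assay compound 2 gives > 5000 nM, also a limit.
Compound 3 `CCCCOc1ccc(CN(Cc2ccc(C(C)(C)C)cc2)Cc2cc3cc(C)ccc3[nH]c2=O)cc1`: in this assay compound 3 gives > 5000 nM, again a limit.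

Compound 3 therefore stands at the limit shared by two of the three values (the limit of > 5000 nM in this assay, at which 2 of the 3 values shown sit). Compound 1 sits at a separate limit (the limit of > 10000 nM in this assay, at which 1 of the 3 values shown sits). Compound 4 `Cc1ccc2[nH]c(=O)c(CN(Cc3ccc(OCCO)cc3)Cc3ccc(C(C)(C)C)cc3)cc2c1` differs from compound 3 by hydroxy in place of ethyl on a saturated chain carbon, two bonds along the chain from an oxygen on an aromatic ring. Every measured step runs between limits: a step that the two limits leave unreadable from compound 1 to compound 2, a step that the two limits leave unreadable from compound 1 to compound 3 and a step that the two limits leave unreadable from compound 2 to compound 3, so none has a readable size and none bears a number on this change. Within the data shown here, the values show only that no compound reached measurable toxicity in this test. For compound 4, the step is expected to be a step that the limit leaves unreadable from compound 3 to compound 4. Compound 4 is estimated at 10000 nM, between 4000 nM and 30000 nM.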

Compound 4, half-maximal cytotoxic concentration: > 5000 nM
Compound 4: only a limit was reported; the forecaster's own chance of this, stated with the estimate: 85%; the middle value does not contradict the limit.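

Compound 4 also gives only a limit, so its steps from compound 1, compound 2 and compound 3 cannot be read. The compounds shown leave open at what concentration any of them turns toxic in this assay.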